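From benzyloxy to diethylamino on a carbonyl carbon

The source may report more compounds than this note shows. Statements on the series, on what has been measured and on what is new or still open speak of the compounds shown alone.

Of the compounds shown here, two with a shared core have been measured so far. For the measured compounds named here, in a functional assay on A549 cells (Homo sapiens) for cytotoxicity, read by colorimetric assay and MTT assay (on this read-out higher numbers stand for weaker inhibition and lower numbers for stronger inhibition), compound 1 (`CCOC(=O)Cn1c(=O)c(-c2ccc(OC)cc2)cc2c(OC)cc(OC)cc21`) gives 10000 nM as its reading, and compound 2 (`COc1ccc(-c2cc3c(OC)cc(OC)cc3n(CCC(=O)OCc3ccccc3)c2=O)cc1`) gives 10000 nM as its reading, so compound 2 stands level with its only neighbour. Going by the values given here, the one measured step (no change at the digits printed from compound 1 to compound 2 (within the scatter)) altered the side chain without moving the number.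

The next structure, compound 3 (`CCN(CC)C(=O)CCn1c(=O)c(-c2ccc(OC)cc2)cc2c(OC)cc(OC)cc21`), has diethylamino in place of benzyloxy on a carbonyl carbon. The change takes away the only ring in the leaving group, and the entering group has no ring.

Among the compounds with values here, the single measured step bears on this only indirectly. Within the data shown here, it also changed the group on the same carbonyl carbon and stayed within the scatter, but no measured compound carries diethylamino, so the evidence is thin. The expected step in this assay (no change at the digits printed from compound 2 to compound 3 (within the scatter)) is therefore none beyond the scatter, with either direction possible. For compound 3 the estimated value is 10000 nM (expected range 4000 nM to 25000 nM).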

Compound 3, half-maximal inhibitory concentration: 10000 nM
The estimate for compound 3 equals the measured number at the digits printed; the measured number falls inside the stated range.
By their numbers in this assay, from the lowest: compounds 1, 2 and 3 (each within the scatter of the next).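

Diethylamino in place of benzyloxy on a carbonyl carbon gives no change at the digits printed from compound 2 to compound 3 (within the scatter) in this assay, so this carbonyl carbon now carries a nitrogen group with no ring, and the reading matches that of the benzyloxy compound with its six-membered aromatic ring. Set against the ethoxycarbonyl side chain, (diethylcarbamoyl)methyl gives no change at the digits printed from compound 1 to compound 3 (within the scatter), which means that all three side chains shown, two with an oxygen group on the carbonyl carbon and one with a nitrogen group, read alike and none stands apart. Nothing available explains why the reading holds steady across these groups.

With three equal readings, the compounds shown leave open whether any group on this carbonyl carbon can shift the reading in this cell assay at all. A free carboxylic acid, a primary amine at the end of the side chain or a longer chain would test that, and so would replacing the methoxy groups on the shared core, which stay the same in all three compounds.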